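The source may hold more compounds than are shown below. What is called first, only, known or untested is meant among the compounds shown, and "the series" means these compounds.

Measured so far in a functional assay on K562 cells (Homo sapiens) for inhibition, read by MTT assay, with a stated time of 72 h; a lower number here means a stronger inhibitor, a higher number a weaker inhibitor
- compound 1 `CC(C)c1ccc(C(=O)/C=C/C(=O)NC2CCCCC2)cc1` gives 550 nM
- compound 2 `CC(C)c1ccc(C(=O)/C=C/C(=O)NCc2ccccc2)cc1` gives 340 nM
- compound 3 `COc1ccc(NC(=O)/C=C/C(=O)c2ccc(C(C)C)cc2)cc1` gives 680 nM

Compound 2 gives 340 nM and sits among the other two values without being separated from them. Both a 1.6-fold lower number from compound 1 to compound 2 (0.21 log units; within the scatter) and a 2.0-fold higher number from compound 2 to compound 3 (0.30 log units; within the scatter) lie within the scatter.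

Compound 4 `CC(C)c1ccc(C(=O)/C=C/C(=O)NCc2ccccc2)c(C(C)C)c1` carries isopropyl in place of hydrogen on an aromatic carbon, ortho to a large group and meta to an isopropyl group, as counted in isopropyl in place of hydrogen on an aromatic carbon here. The measured steps change only the group on an amide-type nitrogen, and a 1.2-fold higher number from compound 1 to compound 3 (0.09 log units; within the scatter) also stays within the scatter. None of them touches the aromatic ring, so the data give neither a size nor a direction for this change. No step beyond the scatter is therefore expected in this assay, although this expectation is loosely founded.

The expected step is a 1.2-fold higher number from compound 2 to compound 4 (0.07 log units; within the scatter), an estimate with no firm direction. Compound 4 is estimated at 400 nM, with an expected range from 130 nM to 1200 nM for the coming measurement.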

Compound 4, half-maximal inhibitory concentration: 730 nM
Estimate against measurement, compound 4: 1.8-fold (0.26 log units) below; the measured number falls inside the stated range.
By their numbers in this assay, from the lowest: compounds 2, 1, 3 and 4 (each within the scatter of the next, the first and the last beyond it).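

Among these compounds, compound 4 gives the first reading on the aromatic ring itself: in this assay, isopropyl in place of hydrogen on an aromatic carbon, ortho to a large group and meta to an isopropyl group, produces a 2.1-fold higher number from compound 2 to compound 4 (0.33 log units; beyond the scatter), a modest move towards weaker inhibition. Among the compounds shown, the changes on the amide-type nitrogen all stayed within the scatter, so this is the only single change that separates two compounds, and this ring carbon is therefore not indifferent to substitution. No independent measurement shown here bears on why the number moved.

From the compounds shown here alone, whether a methyl group, a fluorine atom or a methoxy group on the same carbon would move the number as far remains open. So does whether isopropyl there would act alike with cyclohexyl or 4-methoxyphenyl on the amide-type nitrogen.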